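The source may hold more compounds than are shown below. What is called first, only, known or untested is meant among the compounds shown, and "the series" means these compounds.

Measured compounds in a functional assay on the whole organism with Mus musculus as the target, in the writhing test; on this read-out higher numbers stand for an effect only at larger amounts of compound and lower numbers for an effect already at smaller amounts:
Compound 1 `CCCCn1nc2oc(=O)cc(C)c2c1C`: in this assay compound 1 gives only the limit > 100 mg/kg.
Compound 2 `CCCCn1nc(C)c2c(C)cc(=O)oc21`: in this assay compound 2 likewise gives only the limit > 100 mg/kg.
Compound 3 `CCCCCn1nc2oc(=O)cc(C)c2c1C`: in this assay compound 3 gives 60.6 mg/kg.

Compound 2 thus sits at the limit of > 100 mg/kg in this assay, at which 2 of the 3 values shown sit, and no number beyond that limit is known for it. Compound 4 `CCCn1nc(C)c2c(C)cc(=O)oc21` differs from compound 2 by hydrogen in place of methyl on a saturated chain carbon, three bonds along the chain from an aromatic nitrogen. Going by the values given here, the one measured step of the same kind runs toward the longer chain: an at least 1.6-fold lower number from compound 1 to compound 3 (0.21 log units; that floor lies within the scatter), a shift within the scatter. The change of butyl to propyl in compound 2 therefore gives no reason to expect a lower number, and any higher number would remain beyond the limit. Compound 4 is expected to give a limit again, with the estimate 150 mg/kg (80 mg/kg to 300 mg/kg) and an expected step that the limit leaves unreadable from compound 2 to compound 4 no larger than the scatter.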

Compound 4, dose for half-maximal effect: 54.3 mg/kg
For compound 4 the middle estimate is 2.8-fold (0.44 log units) above the measured one; the measured number lies below the stated range.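

In this assay the change of butyl to propyl gives an at least 1.8-fold lower number from compound 2 to compound 4 (0.26 log units; that floor lies within the scatter), and a measured number now stands where the core of compound 2 had shown only a limit. The lengthening seen on the other core therefore does not carry over, and the direction of this change depends on the core: the same change on two cores in this assay, an at least 1.6-fold lower number (0.21 log units; that floor lies within the scatter) from compound 1 to compound 3 and an at least 1.8-fold higher number (0.26 log units; that floor lies within the scatter) from compound 4 to compound 2, at least 3.0-fold (0.48 log units) apart, beyond the scatter of two such steps

As far as these compounds go, how an ethyl chain, a hexyl chain or a chain carrying an amine would read on either core stays open. From the compounds shown here alone, the full size of the step also stays open, as compound 2 remains a limit.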